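Removing a Methyl from the Weakest Binder

The source may report more compounds than this note shows. Statements on the series, on what has been measured and on what is new or still open speak of the compounds shown alone.

Compound 2 `Cc1nc(NCc2ccc(C(=O)O)cc2)c2cn[nH]c2n1` is the weakest of three compounds in an assay for inhibition of Indoleamine 2,3-dioxygenase 1 (Homo sapiens), read by spectrophotometry, with a stated time of 180 min, tested at 10 uM; on this read-out higher numbers stand for a stronger effect at the one concentration tested and lower numbers for a weaker effect: compound 2 gives 5%. Compound 1 `O=C(O)c1cc(CNc2cc(Br)cc3[nH]ncc23)ccc1O` gives 38%, and compound 3 `Oc1ccc(CNc2cc(Br)cc3[nH]ncc23)cc1` gives 70%. Both lie beyond the scatter above compound 2, so compound 2 counts as the weakest. Going by the values given here, the only single-site step among the measured compounds is a number 32 percentage points higher from compound 1 to compound 3 (beyond the scatter), which concerns a carboxy group on a different core and says nothing about a methyl.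

Compound 4 `O=C(O)c1ccc(CNc2ncnc3[nH]ncc23)cc1` keeps the core of compound 2 and differs from it by hydrogen in place of methyl on an aromatic carbon. Among the compounds with values here, no measured pair exchanges a methyl for a hydrogen, so there is no step to lean on, and the change removes only a single carbon. For compound 4 the step expected is a number 3 percentage points higher from compound 2 to compound 4 (within the scatter), none beyond the scatter. Compound 4 is therefore estimated at 8%, within a range from 0% to 25%.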

Compound 4, a percentage reported as inhibition, at one concentration (the size of the read-out at that concentration, not a potency): 3%
For compound 4 the middle estimate is 5 percentage points above the measured one; the measured number falls inside the stated range.
By their numbers in this assay, from the lowest: compounds 4 and 2 (each within the scatter of the next); then compound 1; then compound 3.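

Going by these compounds alone, at the aromatic carbon between two ring nitrogen atoms, this is the first direct test of the change, and in this assay hydrogen in place of methyl gives a number 2 percentage points lower from compound 2 to compound 4 (within the scatter). So this single carbon makes no readable difference here, although compound 2 and compound 4 both sit so low on the read-out that the pair says little about how the methyl would behave in a compound with a stronger effect. Nothing measured on these compounds offers an explanation for this result.

As far as these compounds go, whether an amine or a longer chain on this same carbon would shift the number remains open. From the compounds shown here alone, it is also open whether replacing the carboxy group of compound 4 with hydrogen would raise its number, as the same exchange did on the different core of compound 1.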